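Hydroxyphenyl for Methylphenyl on the Carbonyl Carbon

The compounds below may be only part of what the source reports. "The series", "measured", "known", "first", "only" and "open" are said of these compounds alone.

Of the compounds shown here, two sharing one core have been measured in a functional assay on HCT-116 cells (Homo sapiens) for cytotoxicity, read by MTT assay, with a stated time of 48 h; on this read-out higher numbers stand for weaker inhibition and lower numbers for stronger inhibition. Compound 1 `O=C(/C=C/c1ccc2c(c1)B(O)OC2)c1cccs1` gives 14200 nM. Compound 2 `Cc1ccc(C(=O)/C=C/c2ccc3c(c2)B(O)OC3)cc1` gives 10500 nM, the lowest of the two numbers, yet the step of a 1.4-fold lower number from compound 1 to compound 2 (0.13 log units; within the scatter) lies within the scatter, so the two compounds cannot be ranked against each other.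

Compound 3 `O=C(/C=C/c1ccc2c(c1)B(O)OC2)c1cccc(O)c1` has not yet been measured. It differs from compound 2 by 3-hydroxyphenyl in place of 4-methylphenyl on a carbonyl carbon. For the measured compounds named here, the only measured step at the same place, a 1.4-fold lower number from compound 1 to compound 2 (0.13 log units; within the scatter), stayed within the scatter, and no measured compound carries a hydroxyl on the ring attached to the carbonyl carbon, so nothing among the data points to a large change. The expectation is therefore a step of a 1.1-fold lower number from compound 2 to compound 3 (0.02 log units; within the scatter), which means no step beyond the scatter. Compound 3 is estimated at 10000 nM, with a range from 4000 nM to 25000 nM.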

Compound 3, half-maximal inhibitory concentration: 6500 nM
For compound 3 the middle estimate is 1.5-fold (0.19 log units) above the measured one, and the stated range covers the measured number.
By their numbers in this assay, from the lowest: compounds 3, 2 and 1 (each within the scatter of the next, the first and the last beyond it).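

In this assay, for the compounds shown here, the exchange of thiophen-2-yl for 3-hydroxyphenyl on the carbonyl carbon gives a 2.2-fold lower number from compound 1 to compound 3 (0.34 log units; beyond the scatter) and so provides the first step at this position to pass the scatter, though only a modest one. Against 4-methylphenyl, the same group gives a 1.6-fold lower number from compound 2 to compound 3 (0.21 log units; within the scatter) and stays within the scatter, so compound 3 separates from compound 1 but not from compound 2. No evidence is at hand to account for either step.

The compounds shown leave open whether the hydroxyl contributes anything to the separation from compound 1, as a plain phenyl group does not appear among them. They also leave open how an amine or a carboxylic acid in place of that hydroxyl would read in this assay and whether any such group would give a step larger than this modest one.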